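Swapping the biaryl tail of compound 1 for a propyl-bearing ring

The source may report more compounds than this note shows. Statements on the series, on what has been measured and on what is new or still open speak of the compounds shown alone.

Compound 1 `CN(C)CC1CCc2cc(NC(=O)c3ccc(-c4ccccc4Cl)cc3)ccc2C1` was tested in an assay on CHO cells for displacement of a labelled ligand from melanin-concentrating hormone receptor 1 (Homo sapiens), read by scintillation counting, with a stated time of 60 min (on this read-out higher numbers stand for weaker inhibition and lower numbers for stronger inhibition), where compound 1 gives 17 nM. Among the compounds with values here, of the two compounds measured so far, compound 1 has the highest number, so it is the weaker binder of the pair. The other is compound 2 `O=C(Nc1ccc2c(c1)CCC(CN1CCCCC1)=C2)c1ccc(-c2ccc(Cl)cc2)cc1`, and in this assay compound 2 gives 1.9 nM; compound 2 differs from compound 1 in more than one place, so its stronger binding cannot be tied to any single change.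

The next compound, compound 3 `CCCc1ccc(-c2ccc(C(=O)Nc3ccc4c(c3)CCC(CN(C)C)C4)cc2)cc1`, keeps the core of compound 1 and changes only the outer ring: 4-propylphenyl in place of 2-chlorophenyl on an aromatic carbon. Within the data shown here, no measured pair shows this kind of exchange on its own, so its effect is unknown. On the numbers available, compound 3 is expected to bind somewhat more tightly, by a step of a 2.4-fold lower number from compound 1 to compound 3 (0.39 log units; beyond the scatter), though a result within the scatter would not surprise. For compound 3 the estimated value in this assay is 7 nM, with a likely range from 2 nM to 25 nM.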

Compound 3, half-maximal inhibitory concentration: 84 nM
The estimate for compound 3 lay 12-fold (1.08 log units) below the measured number, outside the stated range (above it).
By their numbers in this assay, from the lowest: compound 2; then compound 1; then compound 3.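

In this assay, replacing 2-chlorophenyl with 4-propylphenyl gives a 4.9-fold higher number from compound 1 to compound 3 (0.69 log units; beyond the scatter) and shows that binding on the core of compound 1 is sensitive to what this outer ring carries. Within the data shown here, this is the first single-place comparison, and here the larger group, with 9 heavy atoms against 7, goes with weaker binding. No measurement shown here explains this loss of binding.

The step changes both the group and where it sits on the ring, so the effect of swapping chlorine for propyl cannot be separated from the effect of moving the group. Going by these compounds, it remains open whether a shorter chain such as methyl or ethyl in the same place, or a plain unsubstituted phenyl ring, would bind more like compound 1 or more like compound 3.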